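The source may hold more compounds than are shown below. What is called first, only, known or untested is meant among the compounds shown, and "the series" means these compounds.

Compound 1 `NS(=O)(=O)c1ccc(N2N=C(c3ccc(OCc4ccccc4)cc3)CC2c2ccccc2)cc1` gives 80000 nM in an ADME assay on BHK-21 cells (Mesocricetus auratus) for cytotoxicity, read by MTT assay, with a stated time of 72 h; on this read-out lower numbers stand for higher toxicity in this test and higher numbers for lower toxicity in this test.
Compound 2 `NS(=O)(=O)c1ccc(N2N=C(c3ccc(OCc4ccccc4)cc3)CC2c2ccc(F)cc2)cc1` gives 60000 nM in this assay.
Compound 3 `NS(=O)(=O)c1ccc(N2N=C(c3ccc(Oc4ccccc4)cc3)CC2c2ccc(F)cc2)cc1` gives 8000 nM in this assay.

Compound 2 holds the second highest of the three numbers in this assay. Its nearest neighbour is compound 1, which gives 80000 nM; the step of a 1.3-fold lower number from compound 1 to compound 2 (0.12 log units; within the scatter) lies within the scatter, so the two compounds cannot be ordered. Compound 3 is furthest away, and the step of a 7.5-fold lower number from compound 2 to compound 3 (0.88 log units; beyond the scatter) lies beyond it.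

Compound 4 `Cc1ccc(C2CC(c3ccc(OCc4ccccc4)cc3)=NN2c2ccc(S(N)(=O)=O)cc2)cc1` differs from compound 2 at one place: methyl in place of fluoro on an aromatic carbon. The fluoro leaves and a methyl enters, on an aromatic carbon of a six-membered aromatic ring of carbon only, para to a large group.

Among the measured compounds shown here, only one measured step touches that place, the exchange of hydrogen for fluoro from compound 1 to compound 2, and it moved the number by a 1.3-fold lower number from compound 1 to compound 2 (0.12 log units; within the scatter), within the scatter. The step of a 7.5-fold lower number from compound 2 to compound 3 (0.88 log units; beyond the scatter) concerns the oxygen on the other aromatic ring and does not bear on this change. Nothing measured here speaks for a shift in either direction, so no step beyond the scatter is expected in this assay.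

Compound 4 is therefore expected to give about 60000 nM, in the range 25000 nM to 130000 nM, which means an expected step of no change at the digits printed from compound 2 to compound 4 (within the scatter).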

Compound 4, half-maximal cytotoxic concentration: 32000 nM
For compound 4 the middle estimate is 1.9-fold (0.27 log units) above the measured one; low and high end bracket the measured number.
By their numbers in this assay, from the lowest: compound 3; then compounds 4, 2 and 1 (each within the scatter of the next, the first and the last beyond it).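

Among the compounds shown here, with methyl on this aromatic carbon, the position shows a measurable response in this assay for the first time: a 2.5-fold lower number from compound 1 to compound 4 (0.40 log units; beyond the scatter), a modest step, whereas the only earlier step at this place, from hydrogen to fluoro, stayed within the scatter. Methyl and fluoro themselves cannot be ordered, since a 1.9-fold lower number from compound 2 to compound 4 (0.27 log units; within the scatter), so the data separate the 4-methylphenyl compound from the unsubstituted phenyl compound but not from the 4-fluorophenyl compound, and the response at this place remains small beside the step seen at the oxygen on the other aromatic ring. Nothing available here explains why methyl at this place gives a step beyond the scatter from compound 1.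

The compounds shown leave open whether other groups on this aromatic carbon, such as a methoxy group, an amine or a carboxylic acid, would stay close to these numbers or move further from them. They also leave open whether methyl in place of fluoro would give a similar step on the phenoxy scaffold of compound 3, where the number in this assay already stands well apart from those of the benzyloxy compounds.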